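This account rests on a few compounds, and the source may have more. Where it says the series, first, only, none or still open, it means among the compounds named here.

Series notes. Compound 1, `CC(C)(O)COc1ccc2c(Oc3ccc(Nc4nccc5[nH]cc(-c6ccccc6)c(=O)c45)cc3F)ccnc2c1`, has been measured in an ADME assay on microsomes from liver (Rattus norvegicus) for metabolic stability (a lower number here means that the compound disappears faster, a higher number that the compound lasts longer), and gives 5.37 h. That is the highest of the two numbers at hand: the other measured compound, compound 2, `COCCOc1cc2nccc(Oc3ccc(Nc4nccc5[nH]cc(-c6ccc(F)cc6)c(=O)c45)cc3F)c2cc1OC`, gives 1.06 h in this assay, a lower number, and the gap between the two stands beyond the usual scatter. Among the measured compounds shown here, compound 2 differs from compound 1 in more than one place, so no single-point step connects them and nothing about the separate parts of that difference can be read from the pair.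

The next compound, compound 3, `CC(C)(O)COc1ccc2c(Oc3ccc(Nc4nccc5[nH]cc(-c6ccc(F)cc6)c(=O)c45)cc3F)ccnc2c1`, is not yet measured. It differs from compound 1 in one place: fluoro in place of hydrogen on an aromatic carbon. For the measured compounds named here, for a change of this kind, with no matched pair in the data to lean on, the step from compound 1 to compound 3 in this assay is expected to be small, close to no change, and most likely within the scatter, with direction uncertain. Compound 3 is therefore expected to give about 6.5 h in this assay, in a range from 3.2 h to 13 h, meaning an expected step of a 1.2-fold higher number from compound 1 to compound 3 (0.08 log units; within the scatter).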

Compound 3, half-life: 4.14 h
Estimate against measurement, compound 3: 1.6-fold (0.20 log units) above; the measured number falls inside the stated range.
By their numbers in this assay, from the lowest: compound 2; then compounds 3 and 1 (each within the scatter of the next).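

Series notes, continued. In this assay, among the compounds shown here, phenyl to 4-fluorophenyl gives the first single-point reading, a 1.3-fold lower number from compound 1 to compound 3 (0.11 log units; within the scatter), so fluoro in place of hydrogen on this aromatic carbon, para to a large group, leaves the two compounds indistinguishable in this read-out. Compound 2 differs from compound 1 in more than one place and could say nothing about this position on its own, whereas this pair isolates it, though for the fluoro group alone and only on the background of compound 1. No measurement at hand bears on why the number holds at this position.

From the compounds shown here alone, it remains open whether this carbon tolerates other groups equally in this assay, for instance a chlorine, a methoxy, a trifluoromethyl, an amine or a carboxylic acid, any of which would show whether the position is insensitive in general or only to the exchange of hydrogen for fluoro. For the compounds shown here, also open is which of the several differences between compound 1 and compound 2 matters in this assay, since no single-point step yet connects compound 2 to the others.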